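The compounds below may be only part of what the source reports. "The series", "measured", "known", "first", "only" and "open" are said of these compounds alone.

Compound 2 `FC(F)(F)c1ccc(Nc2nc(NC3CCCNC3)nc3c2CCN(c2ncccc2C(F)(F)F)CC3)cc1` was measured in a physicochemical assay for solubility, in phosphate buffer, measured as thermodynamic solubility, at pH 2; a lower number here means a less soluble compound, a higher number a more soluble compound. In this assay compound 2 gives > 235 ug/mL, which is a limit of the assay rather than a number. Compound 1 `CN(c1nc2c(c(Nc3ccc(C(F)(F)F)cc3)n1)CCN(c1ncccc1C(F)(F)F)CC2)C1CCCNC1` differs from compound 2 by a methyl in place of hydrogen on a nitrogen on an aromatic ring. In this assay compound 1 gives > 241 ug/mL, again a limit of the assay and not a number. The step that the two limits leave unreadable from compound 1 to compound 2 therefore cannot be read, as the limit of > 235 ug/mL in this assay, at which 1 of the 2 values shown sits, and the limit of > 241 ug/mL in this assay, at which 1 of the 2 values shown sits, show that both values sit at a limit. Within the data shown here, compound 2 thus stands at a limit, and the only comparison available leaves the size of its one step unreadable.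

Compound 3 `CC(C)(C)OC(=O)N1CCCC(Nc2nc3c(c(Nc4ccc(C(F)(F)F)cc4)n2)CCN(c2ncccc2C(F)(F)F)CC3)C1` carries tert-butoxycarbonyl in place of hydrogen on an amine nitrogen in a ring. Among the measured compounds shown here, no measured step bears directly on this change, and the single step that exists is itself unreadable, so no size can be taken from the data; the change is a large one, with seven heavy atoms entering on the amine nitrogen in a ring. Compound 3 is expected to fall below the limit with a step of an at least 15-fold lower number from compound 2 to compound 3 (1.19 log units; beyond the scatter). For compound 3 the estimate in this assay is 15 ug/mL, in a range from 2 ug/mL to 100 ug/mL.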

Compound 3, solubility: 1 ug/mL
For compound 3 the middle estimate is 15-fold (1.18 log units) above the measured one, outside the stated range (below it).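

Placing tert-butoxycarbonyl on an amine nitrogen in a ring, where compound 2 has hydrogen, gives the first step in this assay that can be read: an at least 230-fold lower number from compound 2 to compound 3 (2.37 log units; beyond the scatter). Among these compounds, the earlier step, on the nitrogen on an aromatic ring, cannot be read, so this is the first sign that a change on the shared core can move this read-out well away from the limit of the assay, and that the amine nitrogen in a ring is a position where such a change matters. The size given is only a minimum, because the value of compound 2 is a limit of the assay and not a number: the limit of > 235 ug/mL in this assay, at which 1 of the 3 values shown sits.

As far as these compounds go, what stays open is whether the large drop needs a group as big as tert-butoxycarbonyl, or whether a small acetyl or a plain methyl on the same nitrogen would also bring the number down. From the compounds shown here alone, it is also open whether a longer chain ending in a carboxylic acid at this place would keep the number at the limit, and how far tert-butoxycarbonyl would lower the number on the core of compound 1.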